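Sulfanyl for Dimethylamino: Expectation for Compound 4

A few compounds are considered here, and "the series" means these few. Any claim that something is new, unique, unknown or untested is made for them only; others in the source may bear on it.

Of the compounds shown here, three from one series have been tested in a functional assay on EL4 cells (Mus musculus) for inhibition, tested at 100 uM; on this read-out higher numbers stand for more inhibition at the one concentration tested (going by the name of the read-out) and lower numbers for less inhibition. Compound 2 `CN(C)c1nccc2c1ncn2C1O[C@H](CO)[C@@H](O)[C@H]1O` gives 10% in this assay, the lower of the two numbers recorded. Compound 3 `CC1OC(n2cnc3c(N)nccc32)CC1O` gives 25%, a reading that lies above compound 2 by more than the usual scatter of this assay. For compound 1 `CN(C)c1nccc2c1ncn2[C@H]1C[C@H](O)[C@@H](CO)O1` the reported result < 5% is a limit of the assay and not a number, namely (the limit of < 5% in this assay, at which 1 of the 3 values shown sits).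

Compound 4 `OC[C@H]1OC(n2cnc3c(S)nccc32)[C@H](O)[C@@H]1O` has not yet been measured in this assay. It differs from compound 2 in one place: sulfanyl in place of dimethylamino on an aromatic carbon. Among the compounds with values here, no pair among the measured compounds differs by a change of this kind, so the measured data give no direct guide to its size or direction. Compound 4 is therefore expected to give about 15% in this assay, with a likely range from 0% to 35%. The step from compound 2 to compound 4 is expected to be a number 5 percentage points higher from compound 2 to compound 4 (within the scatter), a change that would stay within the usual scatter of this assay.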

Compound 4, a percentage reported as inhibition, at one concentration (the size of the read-out at that concentration, not a potency): < 5%
Compound 4: only a limit was reported (the forecaster's own chance of this, stated with the estimate: 25%); middle value at least 10 percentage points away from the limit.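

In this assay the reading of compound 4 is a limit of the assay and not a number: the limit of < 5% in this assay, at which 2 of the 4 values shown sit. This gives the first step read at this aromatic carbon, next to the ring nitrogen, with sulfanyl in place of dimethylamino: the change gives a number at least 5 percentage points lower from compound 2 to compound 4 (that floor lies within the scatter). The data therefore give no sign of a rise in inhibition with this change, and because the step is only a floor, they do not fix its true size.

The compounds shown leave open whether any group on this carbon can lift the reading clearly above that of compound 2. They also do not tell how a methoxy group, a methylamino group or a longer alkylamine chain would read in this assay at this position on the same core.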